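Cyclobutyl in place of tert-butyl on an inactive sulfonamide

The source may hold more compounds than are shown below. What is called first, only, known or untested is meant among the compounds shown, and "the series" means these compounds.

Compound 1 `CCN(CC)S(=O)(=O)c1ccc(S(=O)(=O)N2CCC[C@@H](C(=O)N3CCC(c4nc(C(C)C)no4)CC3)C2)cc1` gives > 10000 nM in a functional assay on MIA PaCa-2 cells (Homo sapiens) for inhibition, read by MTT assay, with a stated time of 3 days (on this read-out higher numbers stand for weaker inhibition and lower numbers for stronger inhibition), which is a limit of the assay and not a number.
Compound 2 `CC(C)c1noc(N2CCN(C(=O)[C@@H]3CCCN(S(=O)(=O)c4ccc(S(=O)(=O)NC(C)(C)C)cc4)C3)CC2)n1` gives > 10000 nM in this assay, again a limit of the assay.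
Compound 3 `CCOC(=O)[C@@H]1CCCN(S(=O)(=O)c2ccc(S(=O)(=O)N(CC)CC)cc2C)C1` gives > 10000 nM in this assay, also a limit of the assay.

Compound 2 therefore stands where every measured compound stands: at the limit, since all three values sit there (the limit of > 10000 nM in this assay, at which 3 of the 3 values shown sit). Among the compounds with values here, no two of the measured compounds differ from one another in a single place, so no measured step is available and nothing can be said about how a single change moves the read-out.

Compound 4 `CC(C)c1noc(N2CCN(C(=O)[C@@H]3CCCN(S(=O)(=O)c4ccc(S(=O)(=O)NC5CCC5)cc4)C3)CC2)n1` differs from compound 2 by cyclobutyl in place of tert-butyl on a sulfonamide nitrogen. The two groups carry the same count of heavy atoms, no donors and no acceptors, and the change sits on the sulfonamide nitrogen at the edge of the molecule. With compound 2 at the limit, the step from compound 2 to compound 4 is expected to be none beyond the scatter, that is a step that the limit leaves unreadable from compound 2 to compound 4. Compound 4 is accordingly estimated at 12000 nM, within a range of 4000 nM to 40000 nM, and most likely to be reported only as a limit.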

Compound 4, half-maximal inhibitory concentration: > 10000 nM
Compound 4 ended at the assay's limit; the forecaster's own chance of this, stated with the estimate: 85%; the middle value does not contradict the limit.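

In this assay, compound 2 and compound 4 both end at a limit and not at a number, so the change from tert-butyl to cyclobutyl gives no step that can be read: the limit of > 10000 nM in this assay, at which 4 of the 4 values shown sit.

The compounds shown leave open which change, if any, would give a measurable value in this series.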